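A few compounds are considered here, and "the series" means these few. Any claim that something is new, unique, unknown or untested is made for them only; others in the source may bear on it.

Measured compounds:

Compound 1, `COC(=O)CC/C(C)=C/Cc1c(OC)c(C)c2c(c1OCC#CCN1CCN(c3ccc(C#N)cc3)CC1)C(=O)OC2`: in a functional assay on HT-29 cells (Homo sapiens) for inhibition, read by sulforhodamine B assay (a lower number here means a stronger inhibitor, a higher number a weaker inhibitor), compound 1 gives > 50000 nM, which is a limit of the assay and not a number.
Compound 2, `COC(=O)CC/C(C)=C/Cc1c(OC)c(C)c2c(c1OCC#CCN1CCN(c3ccccc3F)CC1)C(=O)OC2`: in this assay compound 2 gives > 50000 nM, again a limit of the assay.
Compound 3, `COC(=O)CC/C(C)=C/Cc1c(OC)c(C)c2c(c1OCC#CCN1CCN(Cc3ccc(Cl)cc3)CC1)C(=O)OC2`: in this assay compound 3 gives > 50000 nM, also a limit of the assay.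

Compound 3 therefore stands at the same limit as the other two members of the series; no ranking among the three is possible, since every value is a limit (the limit of > 50000 nM in this assay, at which 3 of the 3 values shown sit). The steps between them, a step that the two limits leave unreadable from compound 1 to compound 2, a step that the two limits leave unreadable from compound 1 to compound 3 and a step that the two limits leave unreadable from compound 2 to compound 3, cannot be read in size or direction for the same reason.

Compound 4, `COC(=O)CC/C(C)=C/Cc1c(OC)c(C)c2c(c1OCC#CCN1CCN(C(c3ccccc3)c3ccc(Cl)cc3)CC1)C(=O)OC2`, is the next member to be measured. It differs from compound 3 by phenyl in place of hydrogen on a saturated chain carbon bound to an amine nitrogen in a ring and an aromatic carbon. For the measured compounds named here, none of the measured steps bears on this change: all three are unreadable because each of the values sits at the limit (the limit of > 50000 nM in this assay, at which 3 of the 3 values shown sit). There is thus no measured basis for expecting a step of any particular size or direction in this assay from compound 3 to compound 4.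

Estimate for compound 4 in this assay: expected to give about 60000 nM, within 20000 nM to 200000 nM, most probably reported again as a limit. The step this estimate implies, a step that the limit leaves unreadable from compound 3 to compound 4, is expected to be none readable beyond the scatter.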

Compound 4, half-maximal inhibitory concentration: > 50000 nM
Compound 4 was reported as a limit; the forecaster's own chance of this, stated with the estimate: 85%; the middle value is on the limit's open side.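

In this assay compound 4 gives > 50000 nM, a limit of the assay and not a number. The step from compound 3 to compound 4 cannot be read in size or direction, since both values are limits: the limit of > 50000 nM in this assay, at which 4 of the 4 values shown sit.

The compounds shown leave open whether any substituent on the amine nitrogen in a ring gives a readable inhibition in this series.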